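Two limits, and a nitrile swap still to measure

This account rests on a few compounds, and the source may have more. Where it says the series, first, only, none or still open, it means among the compounds named here.

Measured in a functional assay on A549 cells (Homo sapiens) for cytotoxicity, read by MTT assay, with a stated time of 48 h; on this read-out lower numbers stand for stronger inhibition and higher numbers for weaker inhibition:
Compound 1 `OC[C@@H]1C[C@H](CO)[C@@H]2C(c3ccc(Cl)cc3)=NO[C@H]12`: > 50 ug/mL
Compound 2 `OC[C@@H]1C[C@H](CO)[C@@H]2C(c3ccc(Br)cc3)=NO[C@H]12`: > 50 ug/mL

Compound 2 gives > 50 ug/mL, which is a limit and not a number. Compound 1 gives > 50 ug/mL, also a limit. Compound 3 `N#Cc1ccc(C2=NO[C@@H]3[C@H](CO)C[C@H](CO)[C@H]23)cc1` carries cyano in place of bromo on an aromatic carbon, para to a large group: cyano in place of bromo on an aromatic carbon. Within the data shown here, the only measured step, a step that the two limits leave unreadable from compound 1 to compound 2, gives no size to build on. What remains is the limit of > 50 ug/mL in this assay, at which 2 of the 2 values shown sit, so no step beyond the scatter is expected in this assay. The estimate means a step that the limit leaves unreadable from compound 2 to compound 3, which is an expected step. For compound 3 the expected value is 60 ug/mL, with an estimated range of 25 ug/mL to 120 ug/mL.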

Compound 3, half-maximal inhibitory concentration: > 50 ug/mL
Compound 3 was reported as a limit; the forecaster's own chance of this, stated with the estimate: 80%; the middle value lies beyond the limit too.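

Compound 3 gives > 50 ug/mL, a limit and not a number, so its steps from compound 1 and compound 2 cannot be read. As far as these compounds go, how strongly any of these three compounds acts remains open.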